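This account rests on a few compounds, and the source may have more. Where it says the series, first, only, none or still open, it means among the compounds named here.

Series notes. The shared core of compound 1 `CCCN(CCC)c1cc(C)nc2c(-c3ccc(Cl)cn3)c(C)nn12` is retained in compound 2 `CCCN(CCC)c1cc(C)nc2c(-c3ncc([N+](=O)[O-])cc3C)c(C)nn12` and compound 3 `CCCN(CCC)c1cc(C)nc2c(-c3ncc(N4CCCCC4)cc3C)c(C)nn12`. In an assay on isolated protein for binding affinity to corticotropin-releasing factor receptor 1 (Homo sapiens) (a lower number here means a stronger inhibitor, a higher number a weaker inhibitor), compound 1 gives 88 nM, compound 2 gives 9.1 nM and compound 3 gives 17 nM. Compound 3 thus stands second highest of the three numbers, nearest compound 2 and furthest from compound 1. Compound 4 `CCCN(CCC)c1cc(C)nc2c(-c3ncc(Cl)cc3C)c(C)nn12` differs from compound 3 by chloro in place of piperidin-1-yl on an aromatic carbon. Among the compounds with values here, no measured step sets chloro directly against piperidin-1-yl; the only step at this carbon, a 1.9-fold higher number from compound 2 to compound 3 (0.27 log units; within the scatter), stayed within the scatter, while chloro is the group carried by compound 1, which gives 88 nM. A small shift in this assay toward a higher number is therefore expected, possibly none beyond the scatter. Compound 4 is estimated at 25 nM (range 8 nM to 80 nM), an expected 1.5-fold higher number from compound 3 to compound 4 (0.17 log units; within the scatter).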

Compound 4, inhibition constant: 6.7 nM
Beside the measured number, compound 4's estimate is 3.7-fold (0.57 log units) above it; measured number below the stated range.
By their numbers in this assay, from the lowest: compounds 4, 2 and 3 (each within the scatter of the next, the first and the last beyond it); then compound 1.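

At this carbon, chloro and nitro lie within the scatter of each other in this assay (a 1.4-fold lower number from compound 2 to compound 4 (0.13 log units; within the scatter)), and chloro gives a modest gain over piperidin-1-yl (a 2.5-fold lower number from compound 3 to compound 4 (0.40 log units; beyond the scatter)), so chloro is no liability here. The large step (a 13-fold lower number from compound 1 to compound 4 (1.12 log units; beyond the scatter)) ties the weak number of compound 1 to the missing methyl group, not to the chloro. No data at hand explain either step. As far as these compounds go, whether a methoxy group or a primary amine at this carbon would match chloro stays open, as does the effect of ethyl in place of the methyl group.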